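Alkoxy variation on the shared core: allyl to isopropyl

A few compounds are considered here, and "the series" means these few. Any claim that something is new, unique, unknown or untested is made for them only; others in the source may bear on it.

Compound 2 `C=CCOc1ccc2c(Cl)ccnc2c1` gives 2930 nM in a functional assay on BGC-823 cells (Homo sapiens) for cytotoxicity, read by MTT assay, with a stated time of 48 h (a lower number here means a stronger inhibitor, a higher number a weaker inhibitor), and stands together with compound 1 `CCCCCCOc1ccc2c(Cl)ccnc2c1`, which gives 2380 nM, since the step of a 1.2-fold higher number from compound 1 to compound 2 (0.09 log units; within the scatter) lies within the scatter. Compound 3 `CC(C)Oc1ccc2c(Cl)ccnc2c1` differs from compound 2 by isopropyl in place of allyl on an oxygen on an aromatic ring. Within the data shown here, only that one step bears on the change, both being swaps of a small chain on the same oxygen, and it gave no shift beyond the scatter. Compound 3 is therefore expected to show a step of a 1.0-fold higher number from compound 2 to compound 3 (0.01 log units; within the scatter), within the scatter. The estimate for compound 3 is 3000 nM, with a range of 1500 nM to 6000 nM.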

Compound 3, half-maximal inhibitory concentration: 2630 nM
For compound 3 the middle estimate is 1.1-fold (0.06 log units) above the measured one; measured number inside the range.
By their numbers in this assay, from the lowest: compounds 1, 3 and 2 (each within the scatter of the next).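

Isopropyl in place of allyl on the oxygen on an aromatic ring gives a 1.1-fold lower number from compound 2 to compound 3 (0.05 log units; within the scatter) in this assay so the double bond outside aromatic rings can be lost here without a step beyond the scatter. Isopropyl in place of hexyl gives a 1.1-fold higher number from compound 1 to compound 3 (0.04 log units; within the scatter) and so the three groups on this oxygen, including a branched one, are not told apart by this read-out. No measurement at hand bears on why these groups read alike.

Open, from the compounds shown here alone, is whether this oxygen accepts anything other than a plain hydrocarbon chain: an amine or a carboxylic acid on the chain, or a chain longer than hexyl, could still move the number.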